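Chloro in Place of Fluoro: A Cytotoxicity Comparison

The source may report more compounds than this note shows. Statements on the series, on what has been measured and on what is new or still open speak of the compounds shown alone.

Compound 1, `COc1ccccc1S(=O)(=O)/C=C/c1ncccc1F`: 100%
Compound 2, `COc1ccccc1S(=O)(=O)/C=C/c1ncccc1Cl`: 100%
Compound 3, `COc1ccc(S(=O)(=O)/C=C/c2ncccc2F)cc1`: 94.2%

Three compounds have been examined in an ADME assay on BV-2 cells (Mus musculus) for cytotoxicity, with a stated time of 24 h, tested at 10 uM; on this read-out lower numbers stand for a stronger effect and higher numbers for a weaker effect at the one concentration tested. Compound 1 gives 100% in this assay. Relative to compound 1, compound 2 carries chloro in place of fluoro on an aromatic carbon, and compound 2 gives 100% in this assay; the resulting step is no change at the digits printed from compound 1 to compound 2 (within the scatter). Compound 3 gives 94.2% in this assay, a value that lies within the scatter of those of compound 1 and compound 2, so no order among the three can be claimed. Compound 3 is built from the same atoms as compound 1, joined differently; the difference between the two cores is not broken down here.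

Compound 4, `COc1ccc(S(=O)(=O)/C=C/c2ncccc2Cl)cc1`, has not yet been measured in this assay. It differs from compound 3 by chloro in place of fluoro on an aromatic carbon, the same change at the same place as that separating compound 1 and compound 2. The step from compound 3 to compound 4 is expected to be a number 1.8 percentage points higher from compound 3 to compound 4 (within the scatter), because the same change gave no change at the digits printed from compound 1 to compound 2 (within the scatter). Compound 4 is accordingly expected to give about 96% in this assay, with a likely range from 85% to 105%. This expectation rests on a single earlier pair and on compound 3 alone, and nothing beyond these four compounds is implied.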

Compound 4, a percentage reported as activity, at one concentration (the size of the read-out at that concentration, not a potency): 94.7%
Beside the measured number, compound 4's estimate is 1.3 percentage points above it, and the stated range covers the measured number.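

In this assay, the exchange of chloro in place of fluoro on an aromatic carbon, ortho to a large group and two atoms from the ring nitrogen, gives a number 0.5 percentage points higher from compound 3 to compound 4 (within the scatter) on this second core. Set side by side, the two steps do not differ, and the exchange reads the same on both cores: the same change on two cores in this assay, no change at the digits printed (within the scatter) from compound 1 to compound 2 and a number 0.5 percentage points higher (within the scatter) from compound 3 to compound 4, 0.5 percentage points apart, within the scatter of two such steps Neither step leaves the scatter, so the pairs show only that this exchange produced no readable difference on either core at the one concentration tested, and they do not show an effect of any size that travels from one core to another, nor that the same would hold on a core beyond these two.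

The four compounds carry only fluoro or chloro at this place, which leaves open how a group such as an amine, a nitrile or a carboxylic acid there would read in this assay, and whether any group at this place would give a step beyond the scatter. Single readings at one concentration also leave open how these compounds would read at higher concentrations or over a different exposure time.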